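The source may report more compounds than this note shows. Statements on the series, on what has been measured and on what is new or still open speak of the compounds shown alone.

Compound 1 `Cc1cc(=O)oc2cc(OCC(=O)NN)ccc12`: 874 nM
Compound 2 `Cc1cc(=O)oc2cc(OCc3nnc(S)o3)ccc12`: 918 nM
Compound 3 `Cc1cc(=O)oc2cc(OCC(=O)NNC(=S)Nc3ccc(Cl)cc3)ccc12`: 620 nM

In an assay for inhibition of Amine oxidase [flavin-containing] B (Bos taurus), read by fluorescence, with a stated time of 30 min (a lower number here means a stronger inhibitor, a higher number a weaker inhibitor), compound 3 gives 620 nM, the lowest of the three numbers, although its gaps to compound 1 and to compound 2 both lie within the scatter, so the three compounds cannot be separated on these data. Among the measured compounds shown here, the only single-point step measured so far, a 1.1-fold higher number from compound 1 to compound 2 (0.02 log units; within the scatter), concerns the tail on the chain carbon and says nothing about the shared core.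

Compound 4 `Cc1c(C)c2ccc(OCC(=O)NNC(=S)Nc3ccc(Cl)cc3)cc2oc1=O` differs from compound 3 by methyl in place of hydrogen on an aromatic carbon. For the measured compounds named here, no measured step touches a change of this kind, and nothing in the three numbers points in either direction. In the absence of any bearing step, the expectation for compound 4 in this assay is a number close to that of compound 3.

Compound 4 is therefore expected to give about 600 nM, with a range from 250 nM to 1500 nM. The step expected is a 1.0-fold lower number from compound 3 to compound 4 (0.01 log units; within the scatter), that is, none beyond the scatter.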

Compound 4, inhibition constant: 561 nM
Compound 4: the middle estimate sits 1.1-fold (0.03 log units) above what was measured; low and high end bracket the measured number.
By their numbers in this assay, from the lowest: compounds 4, 3, 1 and 2 (each within the scatter of the next).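

In this assay, methyl in place of hydrogen on this aromatic carbon, ortho to a methyl group and two atoms from the ring oxygen, gives a 1.1-fold lower number from compound 3 to compound 4 (0.04 log units; within the scatter), so the added methyl brings no change that can be told from the scatter. Among the compounds shown here, this is the first measured step on the shared core rather than on the tail, and it shows that this position can carry a methyl with the number staying in the same range. No measurement at hand bears on why the step is so small.

The compounds shown leave open whether an ethyl, a phenyl, a methoxy or a chlorine at this carbon would also leave the number in place. They also leave open whether the same methyl would behave alike with the aminocarbamoyl or the 5-sulfanyl-1,3,4-oxadiazol-2-yl tail.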